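This account rests on a few compounds, and the source may have more. Where it says the series, first, only, none or still open, it means among the compounds named here.

Measured compounds:
- Compound 1 `COc1nc(=O)n(C)c(CC(F)(COC(C)=O)COC(C)=O)c1C` gives > 100000 nM in a functional assay on SW-620 cells (Homo sapiens) for antiproliferative activity, read by MTT assay, with a stated time of 72 h; on this read-out higher numbers stand for weaker inhibition and lower numbers for stronger inhibition.
- Compound 2 `COc1nc(=O)n(C)c(CC(O)(CO)CO)c1C` gives > 100000 nM in this assay.
- Compound 3 `Cc1c(CC(O)(CO)CO)n(C)c(=O)[nH]c1=O` gives > 100000 nM in this assay.

Each of these three numbers is a limit of the assay rather than a measured value. Compound 1 reaches only the limit. Compound 2 likewise stops at the limit. Compound 3 also stops at the limit. Compound 1 therefore stands nowhere distinct on the numbers shown: all three values sit at the same limit, as summarised by the limit of > 100000 nM in this assay, at which 3 of the 3 values shown sit, so no ordering among compound 1, compound 2 and compound 3 can be read from them.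

The step from compound 1 to compound 4 `COc1nc(=O)n(C)c(CC(O)(COC(C)=O)COC(C)=O)c1C` is a single change: hydroxy in place of fluoro on a saturated chain carbon bound to three saturated chain carbons. For the measured compounds named here, no step between two measured compounds is available to guide the size of this change. Given that compound 1, compound 2 and compound 3 all sit at the limit, the expectation is that the change from fluoro to hydroxy on the saturated chain carbon will produce no movement beyond the scatter, and that compound 4 will again reach only the limit. The estimate for compound 4 is 200000 nM, with a range from 60000 nM to 1000000 nM, an expected step that the limit leaves unreadable from compound 1 to compound 4.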

Compound 4, half-maximal inhibitory concentration: > 100000 nM
Compound 4: no number, only a limit (the forecaster's own chance of this, stated with the estimate: 90%); the middle value is on the limit's open side.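

Compound 1 and compound 4 each stop at a limit of the assay rather than a measured number, so no step can be read between them, and the same holds for the rest of the set: the limit of > 100000 nM in this assay, at which 4 of the 4 values shown sit.

The compounds shown leave open whether hydroxy in place of fluoro has any effect on activity, and what change would give a measurable number.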